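Hydroxycoumarin glycine series: removing the ring methyl

This account rests on a few compounds, and the source may have more. Where it says the series, first, only, none or still open, it means among the compounds named here.

Compound 1 `Cc1cc(=O)oc2c(CN(C)CC(=O)O)c(O)ccc12` carries a methyl on the aromatic core, a phenol and a glycine-bearing aminomethyl arm. In an ADME assay on MT4 cells (Homo sapiens) for cytotoxicity, read by MTT assay, with a stated time of 96 h (on this read-out higher numbers stand for lower toxicity in this test and lower numbers for higher toxicity in this test), compound 1 reaches only a limit of the test, > 100000 nM, and no number is known for it. That limit is the point at which its result sits (the limit of > 100000 nM in this assay, at which 1 of the 2 values shown sits). Compound 2 `CCC(=O)Oc1ccc2c(C)cc(=O)oc2c1Cc1c(C)[nH]c2ccccc12`, an ester on the same core with an indolylmethyl arm in place of the glycine group, gives 31000 nM in this assay; no single-point step links it to compound 1, so only the two values themselves are shown here.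

Compound 3 `CN(CC(=O)O)Cc1c(O)ccc2ccc(=O)oc12` differs from compound 1 in one place: hydrogen in place of methyl on an aromatic carbon. Since compound 1 already sits at the limit, a small step is expected from compound 1 to compound 3 in this assay, a step that the limit leaves unreadable from compound 1 to compound 3, in no direction beyond the scatter. Compound 3 is therefore estimated at 120000 nM, in the range 50000 nM to 300000 nM, with a good chance that this assay again returns only a limit.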

Compound 3, half-maximal cytotoxic concentration: > 100000 nM
Compound 3 ended at the assay's limit; the forecaster's own chance of this, stated with the estimate: 70%; the middle value is on the limit's open side.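

No step can be read between compound 1 and compound 3, as both results in this assay are limits of the test and not numbers: the limit of > 100000 nM in this assay, at which 2 of the 3 values shown sit.

The compounds shown leave open how far either compound lies beyond that limit, and whether hydrogen in place of methyl on an aromatic carbon changes the half-maximal cytotoxic concentration at all.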